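Chloro for methoxy on two cores of the series

A few compounds are considered here, and "the series" means these few. Any claim that something is new, unique, unknown or untested is made for them only; others in the source may bear on it.

Measured compounds:
compound 1 `Clc1ccc(Oc2cncc(C3=CC4CNCC(C3)C4)c2)cc1` 1.9 nM
compound 2 `COc1ccc(C2=CC3CC(C2)CN(C)C3)cn1` 797 nM
compound 3 `COc1ccc(Oc2cncc(C3=CC4CNCC(C3)C4)c2)cc1` 1.4 nM

Values are from an in vitro assay on SH-EP1 cells for displacement of a labelled ligand from Neuronal acetylcholine receptor; alpha4/beta2 (Homo sapiens); a higher number here means a weaker inhibitor, a lower number a stronger inhibitor. Compound 3 and compound 1 share a core; the step of a 1.4-fold higher number from compound 3 to compound 1 (0.13 log units; within the scatter) rests on chloro in place of methoxy on an aromatic carbon and is within the scatter, so the two values are read as alike. Compound 2 sits on a different core, and the difference between the two cores is not broken down here; its value stands far above those of compound 1 and compound 3, by steps that are beyond the scatter.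

Compound 4 `CN1CC2C=C(c3ccc(Cl)nc3)CC(C2)C1` is the unmeasured partner of compound 2, differing by chloro in place of methoxy on an aromatic carbon. This is the same kind of change as that from compound 3 to compound 1, but not the same: there the place was on an aromatic carbon of a six-membered aromatic ring of carbon only, here it is on a six-membered aromatic ring with 1 nitrogen, next to the ring nitrogen. Given that the first step was within the scatter, compound 4 is expected to stay near compound 2, with an estimated step of a 1.3-fold higher number from compound 2 to compound 4 (0.10 log units; within the scatter). The estimate for compound 4 in this assay is 1000 nM, between 400 nM and 2500 nM.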

Compound 4, inhibition constant: 22 nM
The estimate for compound 4 lay 45-fold (1.66 log units) above the measured number; measured number outside the range, below it.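

In this assay, chloro in place of methoxy on the core of compound 4 gives a 36-fold lower number from compound 2 to compound 4 (1.56 log units; beyond the scatter), so on this core the change alone makes a large difference to the number. The change does not carry over between the two cores with one size of step: the same change on two cores in this assay, a 1.4-fold higher number (0.13 log units; within the scatter) from compound 3 to compound 1 and a 36-fold lower number (1.56 log units; beyond the scatter) from compound 2 to compound 4, 49-fold (1.69 log units) apart, beyond the scatter of two such steps. Among these compounds, this shows that a step read on one core is no guide to the step on the other for this pair of cores, but it does not show which difference between the cores sets the two steps apart, since they differ in more than one place and the change itself sits on a six-membered aromatic ring with 1 nitrogen, next to the ring nitrogen, only in compound 4.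

Still open, as far as these compounds go, is whether a fluoro, a nitrile or an amine at that place on the core of compound 4 would read like chloro or like methoxy. Also open, from the compounds shown here alone, is whether any other core follows either of the two steps.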